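The compounds below may be only part of what the source reports. "The series", "measured", "known", "first", "only" and "open" are said of these compounds alone.

Values so far in an ADME assay on HEK293 cells (Homo sapiens) for cytotoxicity, with a stated time of 72 h; on this read-out lower numbers stand for an effect already at smaller amounts and higher numbers for an effect only at larger amounts of compound:
Compound 1 `O=C(Nc1cccc(-c2ccccc2)c1)c1cc([N+](=O)[O-])ccc1Cl` gives 22000 nM as a measured number
Compound 2 `O=C(Nc1cccc(-c2nc3ccccc3o2)c1)c1cc([N+](=O)[O-])ccc1Cl` gives > 25000 nM as a limit
Compound 3 `O=C(Nc1cccc(-c2nc3ccccc3[nH]2)c1)c1cc([N+](=O)[O-])ccc1Cl` gives > 27000 nM as a limit

From the compounds shown here alone, compound 2 has only a limit in this assay and no exact number, so its true place among the three stays open. Compound 4 `O=C(Nc1cc(-c2nc3ccccc3o2)ccc1F)c1cc([N+](=O)[O-])ccc1Cl` is compound 2 with one change: fluoro in place of hydrogen on an aromatic carbon. Within the data shown here, no measured step adds a fluoro, so the evidence is indirect. The two steps with a readable floor swap a different group: an at least 1.1-fold higher number from compound 1 to compound 2 (0.05 log units; that floor lies within the scatter) and an at least 1.2-fold higher number from compound 1 to compound 3 (0.08 log units; that floor lies within the scatter) show no shift that can be told from the scatter. The third, a step that the two limits leave unreadable from compound 2 to compound 3, gives nothing to read. On that basis, no step beyond the scatter is expected in this assay, in either direction, and the expected step is a number no higher from compound 2 to compound 4 (the limit leaves the size open) as a working figure. Compound 4 may well return only a limit too. Compound 4 is estimated at 25000 nM, with an expected range from 12000 nM to 50000 nM as the likely span.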

Compound 4, half-maximal effective concentration: > 25000 nM
Compound 4 gave a limit, no number; the forecaster's own chance of this, stated with the estimate: 60%; the middle value lies on the limit itself.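

In this assay, among these compounds, compound 2 and compound 4 both stand only as limits, and no step between them can be read. From the compounds shown here alone, whether fluoro in place of hydrogen on this aromatic carbon moves the number at all, in either direction, stays open.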